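Chloro for methyl on two different cores in mouse exposure

The source may report more compounds than this note shows. Statements on the series, on what has been measured and on what is new or still open speak of the compounds shown alone.

Compound 1 `CC/C(=C(/c1ccc(/C=C/C(=O)O)cc1)c1ccc2[nH]ncc2c1)c1ccc(C#N)cc1C`, compound 2 `CC/C(=C(/c1ccc(/C=C/C(=O)O)cc1)c1ccc2[nH]ncc2c1)c1ccc(C#N)cc1Cl` and compound 3 `CC/C(=C(/c1ccc(/C=C/C(=O)O)cc1)c1ccc2[nH]ncc2c1)c1ccncc1C` have been measured in an ADME assay on the whole organism for pharmacokinetics, with Mus musculus as the target, at a dose of 10 mg/kg by the oral route; a higher number here means more compound in the circulation at the dose given, a lower number less compound in the circulation. Compound 1 gives 4300 ng.h/mL, and compound 2, which carries the change (chloro in place of methyl on an aromatic carbon), gives 2900 ng.h/mL; this change gave a 1.5-fold lower number from compound 1 to compound 2 (0.17 log units; within the scatter). Compound 3 differs from compound 1 in its core, as told by 3-methylpyridin-4-yl in place of 4-cyano-2-methylphenyl on a double-bonded chain carbon bound to a double-bonded chain carbon and a saturated chain carbon. In this assay compound 3 gives 81 ng.h/mL, the lowest of the three numbers: a 53-fold lower number from compound 1 to compound 3 (1.72 log units; beyond the scatter) and a 36-fold lower number from compound 2 to compound 3 (1.55 log units; beyond the scatter).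

Compound 4 `CC/C(=C(/c1ccc(/C=C/C(=O)O)cc1)c1ccc2[nH]ncc2c1)c1ccncc1Cl` is not yet measured. It differs from compound 3 by chloro in place of methyl on an aromatic carbon, the same kind of change as that from compound 1 to compound 2, but not the same one: in compound 1 the place is on a six-membered aromatic ring of carbon only, ortho to a large group and meta to a cyano group, whereas in compound 3 it is on a six-membered aromatic ring with 1 nitrogen, ortho to a large group and two atoms from the ring nitrogen. Because the earlier step was a 1.5-fold lower number from compound 1 to compound 2 (0.17 log units; within the scatter), the step from compound 3 to compound 4 is expected to be small as well, about a 1.4-fold lower number from compound 3 to compound 4 (0.13 log units; within the scatter). Compound 4 is therefore estimated at 60 ng.h/mL in this assay, with a likely range from 20 ng.h/mL to 180 ng.h/mL.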

Compound 4, area under the concentration-time curve: 110 ng.h/mL
Compound 4: the middle estimate sits 1.8-fold (0.26 log units) below what was measured; the measured number falls inside the stated range.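

Chloro in place of methyl on the core of compound 3 gave a 1.4-fold higher number from compound 3 to compound 4 (0.13 log units; within the scatter) in this assay, and set beside the same change on the core of compound 1, the step carries over: the same change on two cores in this assay, a 1.5-fold lower number (0.17 log units; within the scatter) from compound 1 to compound 2 and a 1.4-fold higher number (0.13 log units; within the scatter) from compound 3 to compound 4, 2.0-fold (0.30 log units) apart, within the scatter of two such steps The change of core itself remains large with chloro in place, with a 26-fold lower number from compound 2 to compound 4 (1.42 log units; beyond the scatter), and it is also large in a 39-fold lower number from compound 1 to compound 4 (1.59 log units; beyond the scatter). Within the data shown here, two pairs on two cores show only that this step stayed small in these compounds; they give it no direction and say nothing about a third core or about any other read-out.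

The compounds shown leave open whether another group at this place, such as fluoro, methoxy or an amine, would give a step as small as chloro does on either core. Also open, from the compounds shown here alone, is whether the step would stay as small with an amide in place of the carboxylic acid.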